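Cyclopropyl to cyclohexyl on the amine nitrogen, two cores

The source may report more compounds than this note shows. Statements on the series, on what has been measured and on what is new or still open speak of the compounds shown alone.

Compound 1 `Nc1sc(-c2ccc(Br)cc2)c(-c2ccc(Cl)cc2)c1C(=O)NC1CC1` and compound 2 `Nc1sc(-c2ccc(Br)cc2)c(-c2ccc(Cl)cc2)c1C(=O)NC1CCCCC1` share one core; compound 3 `Clc1ccc(-c2sc3ncnc(NC4CC4)c3c2-c2ccc(Cl)cc2)cc1` and compound 4 `Clc1ccc(-c2sc3ncnc(NC4CCCCC4)c3c2-c2ccc(Cl)cc2)cc1` share another, and the difference between the two cores is not broken down here. In a functional assay on PC-3 cells (Homo sapiens) for cytotoxicity, read by sulforhodamine B assay, with a stated time of 72 h (a higher number here means a weaker inhibitor, a lower number a stronger inhibitor), compound 1 gives 37300 nM and compound 2 gives 28400 nM. The step cyclohexyl in place of cyclopropyl on an amide-type nitrogen produced a 1.3-fold lower number from compound 1 to compound 2 (0.12 log units; within the scatter). For compound 3 in this assay only a limit is reported, > 50000 nM, and it is the limit noted as the limit of > 50000 nM in this assay, at which 1 of the 3 values shown sits.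

Compound 4 carries the same kind of change, (cyclohexyl in place of cyclopropyl on a nitrogen on an aromatic ring); the place differs, on a nitrogen on an aromatic ring whose other neighbours are aromatic carbon rather than on an amide-type nitrogen whose other neighbours are carbonyl carbon. Since compound 1 to compound 2 gave only a 1.3-fold lower number from compound 1 to compound 2 (0.12 log units; within the scatter), the step from compound 3 to compound 4 in this assay is expected to be of similar size, an at least 1.0-fold lower number from compound 3 to compound 4 (0.01 log units; that floor lies within the scatter), and compound 3 starts from a limit, > 50000 nM. Compound 4 is therefore estimated at 48000 nM, between 20000 nM and 120000 nM, with a fair chance that only a limit is again reported.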

Compound 4, half-maximal inhibitory concentration: > 50000 nM
Compound 4 gave a limit, no number; the forecaster's own chance of this, stated with the estimate: 60%; middle value at least 1.0-fold (0.01 log units) from the limit.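

In this assay, within the data shown here, compound 3 and compound 4 are both reported only as limits, so no step between them can be read: the limit of > 50000 nM in this assay, at which 2 of the 4 values shown sit.

The compounds shown leave open whether cyclohexyl in place of cyclopropyl on a nitrogen on an aromatic ring shifts the number at all on the core of compound 3, and how any such step compares with the one on the amide-type nitrogen.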